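This account rests on a few compounds, and the source may have more. Where it says the series, first, only, none or still open, it means among the compounds named here.

Measured compounds:
compound 1 `COc1ccccc1OCCNc1ccc(=O)n(Cc2ccc(OC)c(OC3CCCC3)c2)n1` — > 100000 nM
compound 2 `COc1ccccc1OCCNc1ccc(=O)n(Cc2ccc(OC)c(OCC3CC3)c2)n1` — 45800 nM
compound 3 `COc1ccccc1OCCNc1cnn(Cc2ccc(OC(F)F)c(OCC3CC3)c2)c(=O)c1Cl` — > 100000 nM

In a functional assay on AGS cells (Homo sapiens) for antiproliferative activity, read by MTT assay, with a stated time of 48 h (on this read-out higher numbers stand for weaker inhibition of growth and lower numbers for stronger inhibition of growth), compound 2 gives 45800 nM. For compound 1 the assay reports only a limit, > 100000 nM. For compound 3 the result is likewise a limit, > 100000 nM. Compound 2 and compound 1 differ by cyclopentyl in place of cyclopropylmethyl on an oxygen on an aromatic ring; the step is an at least 2.1-fold higher number from compound 2 to compound 1 (0.33 log units; beyond the scatter), and its size is bounded by the limit of > 100000 nM in this assay, at which 2 of the 3 values shown sit. How the core of compound 2 differs from that of compound 3 is not broken down here.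

Compound 4 `COc1ccccc1OCCNc1cnn(Cc2ccc(OC(F)F)c(OC3CCCC3)c2)c(=O)c1Cl` is not yet measured. It differs from compound 3 by cyclopentyl in place of cyclopropylmethyl on an oxygen on an aromatic ring, the same change as from compound 2 to compound 1. Since compound 3 already sits at the limit > 100000 nM and the earlier step raised the number, compound 4 is expected to sit at a limit as well, with a step that the limit leaves unreadable from compound 3 to compound 4 as the expected step. The estimate for compound 4 is 150000 nM, expected between 60000 nM and 400000 nM.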

Compound 4, concentration for 50% growth inhibition: > 100000 nM
Compound 4: no number, only a limit; the forecaster's own chance of this, stated with the estimate: 85%; the middle value is on the limit's open side.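

The step from compound 3 to compound 4 in this assay cannot be read, as both results are limits: the limit of > 100000 nM in this assay, at which 3 of the 4 values shown sit.

Going by these compounds, whether cyclopentyl in place of cyclopropylmethyl changes growth inhibition on the core of compound 3 remains open.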